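The compounds below may be only part of what the source reports. "The series", "measured", "known", "first", "only" and "open" are said of these compounds alone.

Compound 3 (`CC(C)CNc1nc(N)nc2c1ncn2/C=C1/CC1(CO)CO`) offers no footing: in an ADME assay on MOLT-3 cells (Homo sapiens) for cytotoxicity, with a stated time of 7 days (a lower number here means that less compound is tolerated, a higher number that more compound is tolerated), compound 3 stands as "not determined" (no result reported). Compound 4 (`CCCCCOc1nc(N)nc2c1ncn2/C=C1/CC1(CO)CO`) carries pentyloxy in place of isobutylamino on an aromatic carbon, (pentyloxy in place of isobutylamino on an aromatic carbon). Among the compounds with values here, the only guide is the pair with an oxygen-linked group at that place. Compound 1 (`CCOc1nc(N)nc2c1ncn2/C=C1/CC1(CO)CO`) gives > 20000 nM, which is a limit. Compound 2 (`Nc1nc(OCc2ccccc2)c2ncn(/C=C3/CC3(CO)CO)c2n1`) gives > 20000 nM, again a limit. The change a step that the two limits leave unreadable from compound 1 to compound 2 therefore has no size to carry over, and the series offers only (the limit of > 20000 nM in this assay, at which 2 of the 3 values shown sit). In this assay no readable step can be set out, so compound 4 is expected to stay close to that limit, on the tolerated side. The estimate for compound 4 is 20000 nM, with an expected range of 8000 nM to 40000 nM.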

Compound 4, half-maximal cytotoxic concentration: > 20000 nM
Compound 4 gave a limit, no number; the forecaster's own chance of this, stated with the estimate: 70%; the middle value lies on the limit itself.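

No new step can be read: compound 1, compound 2 and compound 4 each give a limit, not a number, in this assay. The compounds shown leave open how the pentyloxy, ethoxy and benzyloxy compounds differ beyond that limit, and where compound 3 stands.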